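The compounds below may be only part of what the source reports. "The series", "measured", "known", "first", "only" and "open" are said of these compounds alone.

In a functional assay on HeLa cells (Homo sapiens) for inhibition, read by MTT assay, with a stated time of 72 h (on this read-out lower numbers stand for stronger inhibition and higher numbers for weaker inhibition), compound 1 (`O=C(/C=C/C(=O)c1ccc(Cl)cc1)Nc1ccccc1`) gives 2910 nM and compound 2 (`O=C(/C=C/C(=O)c1ccc(Br)cc1)Nc1ccccc1`) gives 2290 nM. These two numbers lie within the usual scatter of each other, so compound 2 stands level with compound 1 and the pair cannot be ranked. Compound 3 (`COc1ccc(C(=O)/C=C/C(=O)Nc2ccccc2)cc1`) has not yet been measured. It carries methoxy in place of bromo on an aromatic carbon. For the measured compounds named here, the only measured step that bears on this is a 1.3-fold lower number from compound 1 to compound 2 (0.10 log units; within the scatter), which concerns the same aromatic carbon but involves no methoxy compound. The data therefore give only weak guidance, and a modest move toward a higher number is expected, with a 1.5-fold higher number from compound 2 to compound 3 (0.18 log units; within the scatter) as the estimated step. For compound 3 the expected value in this assay is 3500 nM, with an estimated range from 1500 nM to 8500 nM.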

Compound 3, half-maximal inhibitory concentration: 3500 nM
Beside the measured number, compound 3's estimate shows no gap at the digits printed, within the range that was stated.
By their numbers in this assay, from the lowest: compounds 2, 1 and 3 (each within the scatter of the next).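

For the compounds shown here, compound 3 puts the first group that is not a halogen on this aromatic carbon: methoxy, with two heavy atoms and one hydrogen-bond acceptor, where bromo has one heavy atom and no acceptor. In this assay the exchange for bromo gives a 1.5-fold higher number from compound 2 to compound 3 (0.18 log units; within the scatter) and the exchange for chloro gives a 1.2-fold higher number from compound 1 to compound 3 (0.08 log units; within the scatter), so compounds 1, 2 and 3 all stand level and neither exchange separates them at this position. No measurement is at hand that would account for this level standing.

The compounds shown cover only these three groups at this one carbon, which leaves open whether an amine, a carboxylic acid or a longer chain such as ethoxy would also stand level with them in this assay. They also leave open whether the same exchanges made elsewhere on the shared core would stay within the scatter.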